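The compounds below may be only part of what the source reports. "The series", "measured", "known", "first", "only" and "open" are said of these compounds alone.

Compound 1 `O=C(N/N=C/c1ccccc1O)c1cc(-c2ccccc2)nn1Cc1ccc(Cl)nc1` gives 5920 nM in a functional assay on A549 cells (Homo sapiens) for cytotoxicity, read by MTT assay, with a stated time of 48 h; a higher number here means a weaker inhibitor, a lower number a stronger inhibitor.
Compound 2 `O=C(N/N=C/c1ccccc1O)c1cc(-c2ccccc2)nn1Cc1ccccc1` gives 11000 nM in this assay.
Compound 3 `CC(C)(C)c1ccc(Cn2nc(-c3ccccc3)cc2C(=O)N/N=C/c2ccccc2O)cc1` gives 6230 nM in this assay.

Compound 3 stands between the other two on these numbers, yet its gaps to compound 1 and to compound 2 are both within the scatter, so no order can be read among the three. Compound 4 `COc1ccc(-c2cc(C(=O)N/N=C/c3ccccc3O)n(Cc3ccc(C(C)(C)C)cc3)n2)cc1` differs from compound 3 in one place: methoxy in place of hydrogen on an aromatic carbon. For the measured compounds named here, no measured step touches this phenyl. The steps of a 1.9-fold higher number from compound 1 to compound 2 (0.27 log units; within the scatter), a 1.1-fold higher number from compound 1 to compound 3 (0.02 log units; within the scatter) and a 1.8-fold lower number from compound 2 to compound 3 (0.25 log units; within the scatter) all concern the group on the saturated chain carbon bound to an aromatic nitrogen, and all lie within the scatter. A step beyond the scatter is therefore not expected; the expected step is a 1.0-fold lower number from compound 3 to compound 4 (0.02 log units; within the scatter). Compound 4 is estimated at 6000 nM, within a range from 2500 nM to 15000 nM.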

Compound 4, half-maximal inhibitory concentration: 4890 nM
Compound 4: middle estimate off by 1.2-fold (0.09 log units), on the high side, and the stated range covers the measured number.
By their numbers in this assay, from the lowest: compounds 4, 1, 3 and 2 (each within the scatter of the next, the first and the last beyond it).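

The step of a 1.3-fold lower number from compound 3 to compound 4 (0.11 log units; within the scatter) is the first change shown on the phenyl of the shared core, not on the group at the saturated chain carbon. In this assay, this position therefore accepts a methoxy, placed para to a large group, with no difference that can be told from the scatter. Nothing available accounts for this result. As far as these compounds go, whether an amine or a carboxylic acid at this place would give a step beyond the scatter remains open. So does whether methoxy would behave the same way on compound 1 or compound 2.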